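The source may report more compounds than this note shows. Statements on the series, on what has been measured and on what is new or still open speak of the compounds shown alone.

Of the compounds shown here, two of a shared core have been measured in a functional assay on SF-539 cells (Homo sapiens) for inhibition, read by sulforhodamine B assay, with a stated time of 48 h; a lower number here means a stronger inhibitor of growth, a higher number a weaker inhibitor of growth. Compound 1 `Nc1cc(N)c2nc(-c3ccccc3)c(Sc3ccc(F)cc3)nc2c1` gives 21400 nM, the higher of the two numbers and so the weaker inhibitor of growth. Compound 2 `COc1cc(CNc2nc3cc(N)cc(N)c3nc2-c2ccccc2)cc(OC)c1OC` gives 1350 nM, a lower number that lies beyond the usual scatter. Compound 3 `Nc1cc(N)c2nc(-c3ccccc3)c(Sc3ccc(Cl)c(Cl)c3)nc2c1` differs from compound 1 in one place: 3,4-dichlorophenyl in place of 4-fluorophenyl on a sulfur. Among the measured compounds shown here, with no measured step of this kind to draw on, the change from compound 1 to compound 3 is expected to be modest, toward a lower number at most, and may fall within the scatter, as a 1.4-fold lower number from compound 1 to compound 3 (0.15 log units; within the scatter). Compound 3 is estimated at 15000 nM, within a range from 6000 nM to 40000 nM.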

Compound 3, concentration for 50% growth inhibition: 14500 nM
Estimate against measurement, compound 3: 1.0-fold (0.01 log units) above; the measured number falls inside the stated range.
By their numbers in this assay, from the lowest: compound 2; then compounds 3 and 1 (each within the scatter of the next).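

On the sulfur of the shared core, 3,4-dichlorophenyl in place of 4-fluorophenyl gives a 1.5-fold lower number from compound 1 to compound 3 (0.17 log units; within the scatter) in this assay, so this step does not separate the two groups. At this position, then, exchanging one fluorine for two chlorines on the same six-membered aromatic ring makes no difference that can be read beyond the scatter. Nothing available explains this result. Still open, as far as these compounds go, is how a quite different group on the sulfur would behave, such as a short alkyl chain, or a phenyl ring carrying an amine or a carboxylic acid.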